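The compounds below may be only part of what the source reports. "The series", "measured", "known", "first", "only" and "open" are said of these compounds alone.

Three close relatives share one core and differ only in the ring attached to the amine nitrogen of the six-membered non-aromatic ring. Compound 1 `Nc1scc(CN2CCN(c3cccc(Cl)c3Cl)CC2)c1C(=O)c1ccc(Cl)cc1` carries a 2,3-dichlorophenyl there; compound 2 `Nc1scc(CN2CCN(c3cc(Cl)cc(Cl)c3)CC2)c1C(=O)c1ccc(Cl)cc1` carries a 3,5-dichlorophenyl; compound 3 `Nc1scc(CN2CCN(c3ccc(F)cc3Cl)CC2)c1C(=O)c1ccc(Cl)cc1` carries a 2-chloro-4-fluorophenyl. In a functional assay on CHO cells with adenosine receptor A1 (Homo sapiens) as the target, read by cAMP accumulation and immunoassay, with a stated time of 6 min, tested at 10 uM (on this read-out lower numbers stand for a stronger effect and higher numbers for a weaker effect at the one concentration tested), compound 1 gives -77%, compound 2 gives -74% and compound 3 gives -70%. Compound 3 has the highest of the three numbers, yet every gap is within the scatter, so the three cannot be told apart: a number 3 percentage points higher from compound 1 to compound 2 (within the scatter), a number 7 percentage points higher from compound 1 to compound 3 (within the scatter) and a number 4 percentage points higher from compound 2 to compound 3 (within the scatter).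

Compound 4 `Nc1scc(CN2CCN(c3cccc(C(F)(F)F)c3)CC2)c1C(=O)c1ccc(Cl)cc1` is not yet measured. It differs from compound 3 as follows: 3-(trifluoromethyl)phenyl in place of 2-chloro-4-fluorophenyl on an amine nitrogen in a ring. All three measured steps bear on this change, since each swaps one substituted phenyl for another at the same nitrogen, and none of them moved the number beyond the scatter. Within the data shown here, the trifluoromethyl group has no measured precedent here, so the expectation rests on those three flat steps alone.

Compound 4 is therefore expected to give -70% in this assay, within a range from -85% to -50%. The step from compound 3 is estimated as no change at the digits printed from compound 3 to compound 4 (within the scatter), a change not expected to exceed the scatter.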

Compound 4, a percentage reported as activity, at one concentration (the size of the read-out at that concentration, not a potency): -80%
Compound 4: middle estimate off by 10 percentage points, on the high side; low and high end bracket the measured number.
By their numbers in this assay, from the lowest: compounds 4, 1, 2 and 3 (each within the scatter of the next).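

In this assay, the ring on the amine nitrogen can carry no chlorine at all and still stay within the scatter of the chlorine-bearing compounds, with a number 10 percentage points lower from compound 3 to compound 4 (within the scatter), a number 6 percentage points lower from compound 2 to compound 4 (within the scatter) and a number 3 percentage points lower from compound 1 to compound 4 (within the scatter). The entering 3-(trifluoromethyl)phenyl has 10 heavy atoms against 8 for the 2-chloro-4-fluorophenyl it replaces, so this position also accepts a group with more heavy atoms and fluorine as its only halogen, and all four compounds remain indistinguishable here. Nothing shown explains this flatness at the position.

Going by these compounds, all four rings carry chlorine or fluorine, so it remains open whether the same flat picture would hold for an unsubstituted phenyl, or for a phenyl bearing an amine, a methoxy group or a carboxylic acid. The read-out also comes from one concentration, so any differences in potency among these four compounds remain open, as does the effect of changes elsewhere on the shared core.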